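From 3-bromobenzyl to 3-nitrobenzyl: compound 1 to compound 4

A few compounds are considered here, and "the series" means these few. Any claim that something is new, unique, unknown or untested is made for them only; others in the source may bear on it.

Series values in a toxicity assay on NIH3T3 cells (Mus musculus) for cytotoxicity, read by resazurin assay (on this read-out higher numbers stand for an effect only at larger amounts of compound and lower numbers for an effect already at smaller amounts), as read so far
compound 1 `COC(=O)c1ccc(NCc2cncn2Cc2cccc(Br)c2)cc1-c1ccccc1` gives > 10000 nM as a limit
compound 2 `CNC(=O)c1ccc(NCc2cncn2Cc2ccc(-c3ccccc3)cc2N)cc1-c1ccccc1` gives > 1000 nM as a limit
compound 3 `c1ccc(-c2ccc(Cn3cncc3CNc3cccc(-c4ccccc4)c3)cc2)cc1` gives 10000 nM as a number

Compound 1 sits on the limit of > 10000 nM in this assay, at which 1 of the 3 values shown sits, and has no number of its own. The next entry is compound 4 `COC(=O)c1ccc(NCc2cncn2Cc2cccc([N+](=O)[O-])c2)cc1-c1ccccc1`, which carries nitro in place of bromo on an aromatic carbon, meta to a large group (nitro in place of bromo on an aromatic carbon). For the measured compounds named here, no measured pair differs in one place only, so the data give no direct size for this change. In this assay, as far as these compounds go, no shift beyond the scatter is expected, and the direction stays open. This expectation rests on compound 1 and its limit of > 10000 nM as the starting point. The expected size is the estimated step of a number no higher from compound 1 to compound 4 (the limit leaves the size open) and no more. Compound 4 is estimated at 10000 nM in this assay, with an expected range from 3000 nM to 30000 nM and a fair chance that only a limit is reported.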

Compound 4, half-maximal effective concentration: > 10000 nM
Compound 4: a limit, no number (the forecaster's own chance of this, stated with the estimate: 60%); the middle value lies on the limit itself.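

In this assay, for the compounds shown here, compound 1 and compound 4 each stand on a limit and not on a number, so no step between them can be read. The compounds shown leave open whether nitro in place of bromo on an aromatic carbon shifts the value at all, and in which direction.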